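Working notes: from compound 2 to compound 4

The source may hold more compounds than are shown below. What is called first, only, known or untested is meant among the compounds shown, and "the series" means these compounds.

compound 1 `COc1cc(C(=O)O)ccc1OCCCCOc1ccc(C(=O)CC(C)C)c(O)c1C` gives 99%
compound 2 `Cc1c(OCCCCOc2cccc(C(=O)O)c2)ccc(C(=O)CC2CCCC2)c1O` gives 99%
compound 3 `Cc1c(OCCCCOc2cccc(C(=O)O)c2)ccc(C(=O)CC(C)C)c1C` gives 106%

In an ADME assay on a cell-free system (plasma, Rattus norvegicus) for metabolic stability, read by LC-MS, with a stated time of 60 min, tested at 100 uM (on this read-out lower numbers stand for a less stable compound and higher numbers for a more stable compound), compound 2 stands at 99% which is level with compound 1 and within the scatter of compound 3. The change to compound 4 `Cc1c(OCCCCOc2ccc(C(=O)O)c(Cl)c2)ccc(C(=O)CC2CCCC2)c1O` is 4-carboxy-3-chlorophenyl in place of 3-carboxyphenyl on an oxygen on a saturated carbon and it puts 4-carboxy-3-chlorophenyl in place of 3-carboxyphenyl on an oxygen on a saturated carbon. For the measured compounds named here, no pair of measured compounds differs in one place, so this assay offers no direct precedent for this change. Compound 1 at 99% and compound 3 at 106% lie within the scatter of each other despite their different structures, so the expected size of the step of a number 1 percentage points higher from compound 2 to compound 4 (within the scatter) is nothing beyond the scatter in either direction. Compound 4 is estimated at 100% with an expected range from 90% to 110% in this measurement.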

Compound 4, percent of the compound remaining: 97%
The estimate for compound 4 lay 3 percentage points above the measured number; the range from low to high includes it.
By their numbers in this assay, from the lowest: compounds 4, 1, 2 and 3 (each within the scatter of the next).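

In this assay, for the compounds shown here, the first one-place comparison, 4-carboxy-3-chlorophenyl in place of 3-carboxyphenyl on an oxygen on a saturated carbon gives a number 2 percentage points lower from compound 2 to compound 4 (within the scatter) and so leaves the read-out unchanged within the scatter. At this position, the added chlorine and the different placement of the carboxylic acid therefore come together with no step beyond the scatter. Nothing available bears on the reason for this result.

As far as these compounds go, the separate contributions of the chlorine and the carboxylic acid placement remain open. So does the reading of an amide in place of the carboxylic acid.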